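A few compounds are considered here, and "the series" means these few. Any claim that something is new, unique, unknown or untested is made for them only; others in the source may bear on it.

Measured compounds:
compound 1 `Cc1cc(S(=O)(=O)/N=C(\N)n2nccc2-c2ccccc2)c(SCc2cccc(Cl)c2)cc1Cl` — 88000 nM
compound 2 `Cc1cc(S(=O)(=O)/N=C(\N)n2nccc2-c2ccccc2)c(SCc2ccccc2)cc1Cl` — 20000 nM
compound 3 `Cc1cc(S(=O)(=O)/N=C(\N)n2nccc2-c2ccccc2)c(SCc2ccccc2C)cc1Cl` — 23000 nM

In a functional assay on MCF7 cells (Homo sapiens) for cytotoxicity, read by MTT assay, with a stated time of 72 h (a lower number here means a stronger inhibitor, a higher number a weaker inhibitor), compound 3 sits close to compound 2, the two being within the scatter of each other, while compound 1 gives a clearly higher number, as a 3.8-fold lower number from compound 1 to compound 3 (0.58 log units; beyond the scatter) shows. Compound 4 `Cc1cc(S(=O)(=O)/N=C(\N)n2nccc2-c2ccccc2)c(SCc2ccccc2Cl)cc1Cl` differs from compound 3 by chloro in place of methyl on an aromatic carbon. Going by the values given here, two measured steps bear on this. A chloro on the same ring, as in compound 1, came with a higher number than the bare ring, a 4.4-fold lower number from compound 1 to compound 2 (0.64 log units; beyond the scatter), whereas a methyl there made no difference beyond the scatter, a 1.2-fold higher number from compound 2 to compound 3 (0.06 log units; within the scatter). Taken together these suggest that swapping methyl for chloro may push the number in this assay upward, though the chloro in compound 1 stands on a different carbon than the one entered here, so the effect is uncertain. Compound 4 is therefore expected to show a 1.5-fold higher number from compound 3 to compound 4 (0.18 log units; within the scatter), a modest rise that may stay within the scatter. The estimate for compound 4 in this assay is 35000 nM, with a range of 15000 nM to 90000 nM.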

Compound 4, half-maximal inhibitory concentration: 24000 nM
For compound 4 the middle estimate is 1.5-fold (0.16 log units) above the measured one; the range from low to high includes it.
By their numbers in this assay, from the lowest: compounds 2, 3 and 4 (each within the scatter of the next); then compound 1.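

In this assay, chloro in place of methyl on this aromatic carbon, ortho to a large group, leaves the number unchanged (a 1.0-fold higher number from compound 3 to compound 4 (0.02 log units; within the scatter)), and chloro in place of hydrogen does the same (a 1.2-fold higher number from compound 2 to compound 4 (0.08 log units; within the scatter)), so compounds 2, 3 and 4 cannot be told apart at this carbon. Chloro as such therefore does not go with a higher number in this small set, for 2-chlorophenyl in place of 3-chlorophenyl still gives a clear step (a 3.7-fold lower number from compound 1 to compound 4 (0.56 log units; beyond the scatter)), which ties the higher number of compound 1 to where its chloro stands. Nothing available explains this difference between the two placements.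

As far as these compounds go, whether an amine or a carboxylic acid on this carbon would also match the bare ring remains open. So does whether a methyl on the carbon carrying chloro in compound 1 would give a number like that of compound 1 or like that of compound 2.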